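The source may hold more compounds than are shown below. What is called first, only, known or untested is meant among the compounds shown, and "the series" means these compounds.

Compound 3 `COc1ccc(CNC(=O)/C=C/c2coc3cc(OC)ccc3c2=O)cc1` belongs to a small set of amides sharing one core, and in a functional assay on L02 cells (Homo sapiens) for inhibition, read by MTT assay, with a stated time of 48 h (a higher number here means a weaker inhibitor, a lower number a stronger inhibitor), compound 3 gives > 200000 nM, which is a limit of the assay and not a measured number. Its two neighbours stand in the same way. Compound 1 `COc1ccc2c(=O)c(/C=C/C(=O)Nc3cccc(Cl)c3)coc2c1` gives > 200000 nM in this assay, again a limit. Compound 2 `COc1ccc2c(=O)c(/C=C/C(=O)Nc3ccccc3)coc2c1` gives > 200000 nM in this assay, likewise a limit. All three values therefore sit at the limit of > 200000 nM in this assay, at which 3 of the 3 values shown sit, and the steps among them, a step that the two limits leave unreadable from compound 1 to compound 2, a step that the two limits leave unreadable from compound 1 to compound 3 and a step that the two limits leave unreadable from compound 2 to compound 3, cannot be read in size or direction.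

The next compound, compound 4 `COc1ccc2c(=O)c(/C=C/C(=O)Nc3ccc(Cl)cc3)coc2c1`, differs from compound 3 in one place: 4-chlorophenyl in place of 4-methoxybenzyl on an amide-type nitrogen. For the measured compounds named here, no measured step among compounds 1, 2 and 3 gives a readable size for swapping the amide substituent, so nothing in the data points to a shift beyond the scatter in this assay. Compound 4 is therefore expected to remain at the same limit, with the step from compound 3 estimated as a number no higher from compound 3 to compound 4 (the limit leaves the size open). For compound 4 the estimate in this assay is 200000 nM, with a range from 100000 nM to 500000 nM.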

Compound 4, half-maximal inhibitory concentration: > 200000 nM
Compound 4 gave a limit, no number (the forecaster's own chance of this, stated with the estimate: 85%); the middle value sits exactly at the limit.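

In this assay compound 4 gives > 200000 nM and this is a limit, not a number. Its steps to compound 1, compound 2 and compound 3 cannot be read, and all four stand together: the limit of > 200000 nM in this assay, at which 4 of the 4 values shown sit.

Going by these compounds, whether any amide substituent on the shared core shifts inhibition in this assay remains open.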